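Oral exposure in mice across a polyol-bearing imidazole set

This account rests on a few compounds, and the source may have more. Where it says the series, first, only, none or still open, it means among the compounds named here.

Compound 1, `CC(=O)c1ncc([C@@H](O)[C@H](O)[C@H](O)CO)s1`: 668 ng.h/mL
Compound 2, `CC(O)c1nc([C@@H](O)[C@H](O)[C@H](O)CO)c[nH]1`: 10300 ng.h/mL
Compound 3, `CC(=O)N/N=C(\C)c1nc([C@@H](O)[C@H](O)[C@H](O)CO)c[nH]1`: 1030 ng.h/mL

The three compounds were compared in an ADME assay on the whole organism (plasma, strain 129/SvEvBrd x C57BL/6) for pharmacokinetics, with Mus musculus as the target, at a dose of 10 mg/kg by the oral route; on this read-out lower numbers stand for lower exposure and higher numbers for higher exposure at the dose given. Compound 2 stands highest of the three numbers. Its nearest neighbour is compound 3, whose value lies beyond the scatter below it, and the furthest is compound 1, which lies still further below, also beyond the scatter. The two compounds with lower exposure both carry a carbonyl-derived group on the aromatic carbon where compound 2 carries its 1-hydroxyethyl group.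

Compound 4, `OC[C@@H](O)[C@@H](O)[C@H](O)c1c[nH]c(-c2ncon2)n1`, has not yet been measured in this assay. It differs from compound 2 in one place: 1,2,4-oxadiazol-3-yl in place of 1-hydroxyethyl on an aromatic carbon. Among the measured compounds shown here, no measured pair in the set isolates this particular exchange, so its effect is not known from the data.

Given that every departure from the 1-hydroxyethyl group among the measured compounds, compound 1 and compound 3 alike, gave a markedly lower exposure than compound 2 at 10300 ng.h/mL, a downward step from compound 2 to compound 4 is expected, a 4.1-fold lower number from compound 2 to compound 4 (0.61 log units; beyond the scatter), beyond the scatter. For compound 4 the exposure is estimated at 2500 ng.h/mL, with a range from 700 ng.h/mL to 8000 ng.h/mL.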

Compound 4, area under the concentration-time curve: 820 ng.h/mL
Compound 4: middle estimate off by 3.0-fold (0.48 log units), on the high side; the measured number falls inside the stated range.
By their numbers in this assay, from the lowest: compounds 1, 4 and 3 (each within the scatter of the next); then compound 2.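

In this assay, among the compounds shown here, the exchange of 1-hydroxyethyl for 1,2,4-oxadiazol-3-yl on this aromatic carbon gives the first step that isolates a change at this position, a 13-fold lower number from compound 2 to compound 4 (1.10 log units; beyond the scatter), and the step is large. With the rest of the molecule unchanged, the exposure at the dose given therefore answers strongly to what stands on this carbon, and the new ring does not keep the high number seen with 1-hydroxyethyl. Compound 4 and compound 3, which share the core but carry different groups here, stand within the scatter of each other, so the high number remains with compound 2 alone among the compounds on this core, and nothing shown gives a measured reason for the step.

The compounds shown leave open whether the hydroxyl of the 1-hydroxyethyl group matters or the whole group does, a question that a plain ethyl group or a 1-aminoethyl group on the same carbon would address. They also leave open whether the loss belongs to 1,2,4-oxadiazol-3-yl in particular or would also follow from another ring here, such as an oxazole or a thiazole.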